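Replacing chloro with cyano in compound 1

The compounds below may be only part of what the source reports. "The series", "measured", "known", "first", "only" and "open" are said of these compounds alone.

In a functional assay on PC-3 cells (Homo sapiens) for antiproliferative activity, read by CCK-8 assay, with a stated time of 72 h (on this read-out lower numbers stand for stronger inhibition and higher numbers for weaker inhibition), compound 1 `Cc1cc(Nc2cc(N3CCN(C)CC3)nc(Nc3ccc(Cl)cc3)n2)n[nH]1` gives 1480 nM, compound 2 `COc1cccc(Nc2nc(Nc3cc(C)[nH]n3)cc(N3CCN(C)CC3)n2)c1` gives 1080 nM and compound 3 `Cc1cc(Nc2cc(N3CCN(C)CC3)nc(Nc3cccc([N+](=O)[O-])c3)n2)n[nH]1` gives 962 nM. Compound 1 stands level with the other two, as its steps to both lie within the usual scatter of repeated measurements.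

Compound 4 `Cc1cc(Nc2cc(N3CCN(C)CC3)nc(Nc3ccc(C#N)cc3)n2)n[nH]1` has not yet been measured. It keeps the core of compound 1 and alters one group, with cyano in place of chloro on an aromatic carbon. Going by the values given here, two measured steps bear on this change, as each also replaces the 4-chlorophenyl group. The first is a 1.4-fold lower number from compound 1 to compound 2 (0.14 log units; within the scatter), and the second is a 1.5-fold lower number from compound 1 to compound 3 (0.19 log units; within the scatter). Among the compounds with values here, neither step goes beyond the scatter, although no measured compound carries a cyano group to test the swap directly. No step beyond the scatter is therefore expected in this assay. The expected change is a 1.3-fold lower number from compound 1 to compound 4 (0.11 log units; within the scatter). For compound 4, the estimated value is 1150 nM, with an expected range from 550 nM to 2400 nM.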

Compound 4, half-maximal inhibitory concentration: 977 nM
Compound 4: the middle estimate sits 1.2-fold (0.07 log units) above what was measured, within the range that was stated.
By their numbers in this assay, from the lowest: compounds 3, 4, 2 and 1 (each within the scatter of the next).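

In this assay, going by these compounds alone, cyano in place of chloro on this phenyl ring gives a 1.5-fold lower number from compound 1 to compound 4 (0.18 log units; within the scatter) and so adds no step beyond the scatter, which is the first direct test of this swap. Compound 4 also stands level with the two compounds that carry other substituted phenyl groups, with a 1.0-fold higher number from compound 3 to compound 4 (0.01 log units; within the scatter) and a 1.1-fold lower number from compound 2 to compound 4 (0.04 log units; within the scatter) and so all four groups on this nitrogen remain indistinguishable on this read-out. No measurement at hand offers an explanation for this lack of separation.

From the compounds shown here alone, whether an amine, a carboxylic acid or a longer chain in this place would produce a step beyond the scatter remains open. Going by these compounds, whether changes elsewhere on the shared core would do so also remains open.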